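The source may report more compounds than this note shows. Statements on the series, on what has been measured and on what is new or still open speak of the compounds shown alone.

Measured compounds:
Compound 1 `CC1=NN(c2cccc(Cl)c2)C(=O)C12C=CC(=O)C=C2c1ccc(C)cc1`, in a functional assay on HCT-116 cells (Homo sapiens) for antiproliferative activity, read by CCK-8 assay, with a stated time of 72 h (a higher number here means a weaker inhibitor, a lower number a stronger inhibitor), compound 1 gives 2400 nM.
Compound 2 `CC1=NN(c2ccccc2)C(=O)C12C=CC(=O)C=C2c1ccccc1`, in this assay compound 2 gives 17800 nM.

Among the measured compounds shown here, of these two numbers, compound 1 has the lower one, and the gap to compound 2 lies beyond the scatter; no single-change step between the measured compounds is available. The unmeasured compound 3 `CC1=NN(c2ccc(Cl)cc2)C(=O)C12C=CC(=O)C=C2c1ccc(C)cc1` differs from compound 1 in one place: 4-chlorophenyl in place of 3-chlorophenyl on an amide-type nitrogen in a ring. For the measured compounds named here, the data hold no measured pair that isolates this change, so no measured step can be used to size it. The change keeps the same atoms and the same substituent on the other ring, and the expectation is that it moves the number in this assay little, if at all, with no clear direction beyond the scatter. Compound 3 is therefore expected to come out near compound 1, with an estimated step of a 1.1-fold higher number from compound 1 to compound 3 (0.03 log units; within the scatter). The estimate for compound 3 is 2600 nM, within a range from 1000 nM to 7000 nM.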

Compound 3, half-maximal inhibitory concentration: 10300 nM
Estimate against measurement, compound 3: 4.0-fold (0.60 log units) below; the whole stated range lies below it.
By their numbers in this assay, from the lowest: compound 1; then compounds 3 and 2 (each within the scatter of the next).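

In this assay, 4-chlorophenyl in place of 3-chlorophenyl on the amide-type nitrogen in a ring gives a 4.3-fold higher number from compound 1 to compound 3 (0.63 log units; beyond the scatter), so the number at this position responds to where the chlorine sits, not only to which group is present. Among the compounds shown here, the two groups have the same atoms and the same counts, and this single-change step is the first that sizes any change at this position, with the lower number going to 3-chlorophenyl in this pair. Nothing measured on these compounds accounts for the difference.

On these data alone, it remains open how a bromophenyl or a methoxyphenyl group would read on this nitrogen. As far as these compounds go, the step also rests on one pair, so it is unknown whether it would persist with a different group, such as an aminophenyl, on the other ring of the shared core.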